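Swapping Hydroxy for Chloro on the Aryl Ketone

The compounds below may be only part of what the source reports. "The series", "measured", "known", "first", "only" and "open" are said of these compounds alone.

Compound 2 `O=C(/C=C/c1cc2ccccc2[nH]c1=O)c1ccc(O)cc1` gives 55000 nM in an ADME assay on SNB-75 cells (Homo sapiens) for cytotoxicity, read by sulforhodamine B assay, with a stated time of 24 h; a lower number here means that less compound is tolerated, a higher number that more compound is tolerated; compound 1 `COc1ccc(C(=O)/C=C/c2cc3ccccc3[nH]c2=O)cc1` gives 47200 nM, and the two stand within the scatter of one another. Among the measured compounds shown here, the only measured step, a 1.2-fold higher number from compound 1 to compound 2 (0.07 log units; within the scatter), touches the same oxygen but is a different kind of change. Compound 3 `O=C(/C=C/c1cc2ccccc2[nH]c1=O)c1ccc(Cl)cc1` carries chloro in place of hydroxy on an aromatic carbon. For the measured compounds named here, no measured step bears on this swap, so the data give no direction. Compound 3 is expected to show only a 1.2-fold lower number from compound 2 to compound 3 (0.09 log units; within the scatter). Compound 3 is estimated at 45000 nM, with a range from 20000 nM to 100000 nM.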

Compound 3, concentration lethal to 50% of the cells: > 100000 nM
Compound 3 gave a limit, no number; the forecaster's own chance of this, stated with the estimate: 10%; middle value at least 2.2-fold (0.34 log units) from the limit.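

Compound 3 stands at a limit of the assay, not at a number: the limit of > 100000 nM in this assay, at which 1 of the 3 values shown sits.

Chloro in place of hydroxy gives an at least 1.8-fold higher number from compound 2 to compound 3 (0.25 log units; that floor lies within the scatter), so this swap alone is not shown to move the result beyond the scatter. Chloro in place of methoxy gives an at least 2.1-fold higher number from compound 1 to compound 3 (0.32 log units; beyond the scatter), the first change at this position to clear the scatter, with more compound tolerated in this assay.

The compounds shown leave open how far past the limit the true value of compound 3 lies. They also leave open whether fluoro, an amine or a carboxylic acid on the same aromatic carbon would behave like chloro.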